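Notes on the series: the isobutoxy step from compound 2

The compounds below may be only part of what the source reports. "The series", "measured", "known", "first", "only" and "open" are said of these compounds alone.

Compound 2 `COc1ccc(-c2nc3cc(/C=C4\SC(=O)N(Cc5cc(OC)c(OC)c(OC)c5)C4=O)ccc3[nH]2)cc1OC` stands lowest of the two numbers measured in a functional assay on HT-1080 cells (Homo sapiens) for inhibition, read by MTT assay, with a stated time of 48 h; on this read-out higher numbers stand for weaker inhibition and lower numbers for stronger inhibition; in this assay compound 2 gives 270 nM. The other measured member, compound 1 `COc1cc(CN2C(=O)S/C(=C\c3ccc4[nH]c(-c5cc(OC)c(OC)c(OC)c5)nc4c3)C2=O)cc(OC)c1OC`, gives 980 nM in this assay. Among the compounds with values here, the single measured step in the set is a 3.6-fold lower number from compound 1 to compound 2 (0.56 log units; beyond the scatter).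

Compound 3 `COc1cc(-c2nc3cc(/C=C4\SC(=O)N(Cc5cc(OC)c(OC)c(OC)c5)C4=O)ccc3[nH]2)ccc1OCC(C)C` has not yet been measured. It differs from compound 2 by isopropyl in place of hydrogen on a saturated chain carbon bound to an oxygen on an aromatic ring; cut one bond further out, the same difference reads methoxy to isobutoxy. Within the data shown here, no measured step touches this place: the step from compound 1 to compound 2 removes a group elsewhere on the core and so gives no direct guidance on lengthening the chain on the oxygen here. Among the measured compounds shown here, with no measured step bearing on the change, no step beyond the scatter is expected in this assay, the expected step from compound 2 to compound 3 being a 1.1-fold higher number from compound 2 to compound 3 (0.05 log units; within the scatter). Compound 3 is therefore estimated at 300 nM in this assay, within a range of 100 nM to 900 nM.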

Compound 3, half-maximal inhibitory concentration: 160 nM
Estimate against measurement, compound 3: 1.9-fold (0.27 log units) above, within the range that was stated.
By their numbers in this assay, from the lowest: compounds 3 and 2 (each within the scatter of the next); then compound 1.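

In this assay, within the data shown here, the step of a 1.7-fold lower number from compound 2 to compound 3 (0.23 log units; within the scatter) is the first reading at this place, and it shows that methoxy can become isobutoxy, with isopropyl in place of hydrogen on the saturated chain carbon bound to the oxygen, without a step beyond the scatter. Among these compounds, the three added carbons therefore leave compound 3 level with compound 2 on this read-out, whereas the only step beyond the scatter in the set remains a 3.6-fold lower number from compound 1 to compound 2 (0.56 log units; beyond the scatter), which is a change at a different place, hydrogen in place of methoxy on an aromatic carbon. No measurement is available that would explain this result or connect it to any property of the added group.

The compounds shown leave open how a longer chain on the same oxygen, or a chain ending in an amine or a carboxylic acid, would read in this assay. With only methoxy and isobutoxy at this place, no trend with chain size can be drawn, and a single step within the scatter does not show how far the place can be extended.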